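Moving the Carboxyl and Adding Chlorine on Compound 2

The source may hold more compounds than are shown below. What is called first, only, known or untested is meant among the compounds shown, and "the series" means these compounds.

Compound 2 `Cc1c(OCCCCOc2cccc(C(=O)O)c2)ccc(C(=O)CC2CCCC2)c1O` holds the higher of the two numbers in an assay on HEK293 cells for positive allosteric modulation of metabotropic glutamate receptor 3 (Rattus norvegicus), read by thallium flux, with a stated time of 2.5 min (a higher number here means a larger maximal response, a lower number a smaller maximal response), giving 92.9%, while compound 1 `COC(=O)c1ccc(OCCCCOc2ccc(C(=O)CC3CCCC3)c(O)c2C)cc1` gives 22%. Going by the values given here, the single measured step, a number 70.9 percentage points higher from compound 1 to compound 2 (beyond the scatter), shows that the aryl group on the chain oxygen governs the maximal response. Compound 3 `Cc1c(OCCCCOc2ccc(C(=O)O)c(Cl)c2)ccc(C(=O)CC2CCCC2)c1O` carries 4-carboxy-3-chlorophenyl in place of 3-carboxyphenyl on an oxygen on a saturated carbon. Among the compounds with values here, no measured step matches this change exactly, so the expectation rests on the large sensitivity seen in a number 70.9 percentage points higher from compound 1 to compound 2 (beyond the scatter). A moderate decrease is expected, a number 27.9 percentage points lower from compound 2 to compound 3 (beyond the scatter). Compound 3 is estimated at 65%, with a range from 30% to 100%.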

Compound 3, largest response reached (reported as percent of maximum), in percent of the reference or control that the assay uses: 40%
Compound 3: middle estimate off by 25 percentage points, on the high side; the range from low to high includes it.
By their numbers in this assay, from the lowest: compound 1; then compound 3; then compound 2.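

In this assay, the aryl group on the chain oxygen proves sensitive to more than the presence of a free carboxyl: 4-carboxy-3-chlorophenyl in place of 3-carboxyphenyl gives a large loss (a number 52.9 percentage points lower from compound 2 to compound 3 (beyond the scatter)). Against 4-(methoxycarbonyl)phenyl, the same group brings only a modest gain (a number 18 percentage points higher from compound 1 to compound 3 (beyond the scatter)), so carrying a carboxyl does not by itself secure the response of compound 2. Nothing measured here explains either step. Because the carboxyl placement and the chlorine change together, the compounds shown cannot separate their shares. Plain 4-carboxyphenyl on the chain oxygen would divide them.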